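This account rests on a few compounds, and the source may have more. Where it says the series, first, only, none or still open, it means among the compounds named here.

Measured compounds:

Compound 1 `O=C(Nc1ccccc1)c1ccc(-c2ncccc2C(F)(F)F)cc1`: in a functional assay for antagonist activity at transient receptor potential cation channel subfamily V member 1 (Rattus norvegicus) (on this read-out lower numbers stand for stronger inhibition and higher numbers for weaker inhibition), compound 1 has "not determined" (no result reported), so no result is reported for it.
Compound 2 `N#Cc1ccc(NC(=O)c2ccc(-c3ncccc3C(F)(F)F)cc2)cc1`: in this assay compound 2 gives 1300 nM.
Compound 3 `Cc1cccnc1-c1ccc(C(=O)Nc2ccc(C(C)C)cc2)cc1`: in this assay compound 3 gives 43 nM.

Compound 3 stands at the lowest of the two numbers available. Its nearest neighbour is compound 2, whose number is far higher, a gap well beyond the usual scatter of repeated measurements; compound 1 adds no number to the comparison. Compound 4 `Cc1cccnc1-c1ccc(C(=O)Nc2ccc(Cl)cc2)cc1` keeps the core of compound 3 and changes one group: chloro in place of isopropyl on an aromatic carbon, at a position described as on an aromatic carbon of a six-membered aromatic ring of carbon only, para to a large group. Going by the values given here, no pair of measured compounds differing in only one place is available, so no measured step can guide this change directly. The expectation is a modest rise in the number for compound 4, that is a somewhat weaker inhibition than compound 3, but not a return to the level of compound 2. Compound 4 is therefore estimated at 150 nM, with a range from 40 nM to 600 nM, which corresponds to an expected step of a 3.5-fold higher number from compound 3 to compound 4 (0.54 log units; beyond the scatter).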

Compound 4, half-maximal inhibitory concentration: 2020 nM
Estimate against measurement, compound 4: 13-fold (1.13 log units) below; measured number above the stated range.
By their numbers in this assay, from the lowest: compound 3; then compounds 2 and 4 (each within the scatter of the next).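

In this assay, putting chloro in place of isopropyl on an aromatic carbon, para to a large group, gives a 47-fold higher number from compound 3 to compound 4 (1.67 log units; beyond the scatter), a large loss of inhibition well beyond the usual scatter. This is the first pair shown that differs in only one place, and it establishes that this position is far from indifferent: on this core, inhibition depends strongly on which group sits there. No measurement shown here explains why the three-carbon isopropyl and the single chlorine differ so much.

From the compounds shown here alone, with only these two groups compared at this position, it remains open whether the trend follows group size or something else, and a methyl, tert-butyl or methoxy group there would test this. Going by these compounds, whether the same swap has a similar effect on the core of compound 2 also remains unknown.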